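Exchange of the unsaturated amide tail on compound 2

The source may hold more compounds than are shown below. What is called first, only, known or untested is meant among the compounds shown, and "the series" means these compounds.

Two members of the series have numbers in a functional assay on A549 cells (Homo sapiens) for antiproliferative activity, read by MTT assay, with a stated time of 72 h; a lower number here means a stronger inhibitor, a higher number a weaker inhibitor. Compound 1 `CC/C=C\C(=O)Nc1cc(Nc2nccc(-c3cn(C)c4ccccc34)n2)c(OC)cc1N(C)CCN(C)C` carries the (but-1-en-1-yl)carbonyl amide, and in this assay compound 1 gives 1530 nM. Compound 2 `C=C(Cl)C(=O)Nc1cc(Nc2nc(C)cc(-c3cn(C)c4ccccc34)n2)c(OC)cc1N(C)CCN(C)C` carries the (1-chloroethenyl)carbonyl amide, and in this assay compound 2 gives 1730 nM. Compound 2 has the higher of the two numbers, but the two values lie within the scatter of each other, so no order between them can be read from the data. Compound 3 `CC/C=C\C(=O)Nc1cc(Nc2nc(C)cc(-c3cn(C)c4ccccc34)n2)c(OC)cc1N(C)CCN(C)C` remains to be measured in this assay. It differs from compound 2 in one place: but-1-en-1-yl in place of 1-chloroethenyl on a carbonyl carbon. Among the measured compounds shown here, no measured pair isolates this change. For the measured compounds named here, the only guidance is that compound 1 also carries the but-1-en-1-yl tail and its value sits within the scatter of compound 2. The expected step is a 1.1-fold lower number from compound 2 to compound 3 (0.03 log units; within the scatter), none beyond the scatter in either direction. Compound 3 is expected at 1600 nM, with a range from 800 nM to 3500 nM.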

Compound 3, half-maximal inhibitory concentration: 1090 nM
Estimate against measurement, compound 3: 1.5-fold (0.17 log units) above, within the range that was stated.
By their numbers in this assay, from the lowest: compounds 3, 1 and 2 (each within the scatter of the next).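

In this assay, the exchange of 1-chloroethenyl for but-1-en-1-yl on a carbonyl carbon can now be read directly as a 1.6-fold lower number from compound 2 to compound 3 (0.20 log units; within the scatter), so with the rest of compound 2 held constant the two tails cannot be told apart. Among the compounds shown here, the same measurement also gives the first reading of methyl in place of hydrogen on an aromatic carbon, with the but-1-en-1-yl tail held constant, as a 1.4-fold lower number from compound 1 to compound 3 (0.15 log units; within the scatter), so neither change at these two positions yet produces a step beyond the scatter. Nothing available bears on the result beyond these numbers.

The compounds shown leave open whether a step beyond the scatter appears at the carbonyl carbon with a tail that carries an amine, such as a dimethylaminobutenyl group, or with a saturated propyl chain in place of the double-bonded tails. Also open, going by these compounds, is whether a larger group on the aromatic carbon, such as ethyl or phenyl in place of methyl, would separate from hydrogen in this assay series.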